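The source may report more compounds than this note shows. Statements on the series, on what has been measured and on what is new or still open speak of the compounds shown alone.

Measured in a functional assay on HepG2 cells (Homo sapiens) for inhibition, read by MTT assay, with a stated time of 48 h; on this read-out higher numbers stand for weaker inhibition and lower numbers for stronger inhibition:
compound 1 `COc1ccc(N(C)c2nc(C)nc3ccccc23)cc1OCCC[Se]C#N` gives 1040 nM
compound 2 `COc1ccc(N(C)c2nc(C)nc3ccccc23)cc1[Se]C` gives 17 nM
compound 3 `COc1ccc(N(C)c2nc(C)nc3ccccc23)cc1[Se]C#N` gives 59 nM

Of these three, compound 3 at 59 nM takes the middle place, with only compound 2 giving a lower number. Compound 4 `COc1ccc(N(C)c2nc(C)nc3ccccc23)cc1OCCCCC[Se]C#N` carries a group of 9 heavy atoms (6 carbon, 1 nitrogen, 1 oxygen, 1 selenium; no ring) in place of a group of 3 heavy atoms (1 carbon, 1 nitrogen, 1 selenium; no ring), on an aromatic carbon at the same site, ortho to a methoxy group. Among the compounds with values here, the closest precedent is an 18-fold lower number from compound 1 to compound 3 (1.25 log units; beyond the scatter) as a large step, since compound 1 also holds its selenium and nitrile at the end of a chain joined through oxygen. Read in reverse, that step points to a large rise in the number. By contrast, a 3.5-fold higher number from compound 2 to compound 3 (0.54 log units; beyond the scatter) concerns only the substituent on selenium and bears little on this change. The expected change is a 15-fold higher number from compound 3 to compound 4 (1.18 log units; beyond the scatter) in this assay and would be large. Compound 4 is estimated at 900 nM with an expected range from 300 nM to 3000 nM in this read-out.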

Compound 4, half-maximal inhibitory concentration: 5210 nM
Beside the measured number, compound 4's estimate is 5.8-fold (0.76 log units) below it, and the stated range ends below it.
By their numbers in this assay, from the lowest: compound 2; then compound 3; then compound 1; then compound 4.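

In this assay, lengthening the chain that ends in selenium and nitrile raises the number further, a 5.0-fold higher number from compound 1 to compound 4 (0.70 log units; beyond the scatter), so chain length matters at this position, beyond the presence of the chain itself. The longer chain also widens the gap to the groups held directly on the aromatic carbon, with an 88-fold higher number from compound 3 to compound 4 (1.95 log units; beyond the scatter) and a 310-fold higher number from compound 2 to compound 4 (2.49 log units; beyond the scatter). Nothing at hand explains these rises. On these data alone, whether a longer chain would raise the number again remains open, as does what a methyl on selenium or a carboxylic acid in place of the nitrile would do at the chain end.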